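Replacing 4-nitrophenyl with 2,3-dichlorophenyl: working notes

This account rests on a few compounds, and the source may have more. Where it says the series, first, only, none or still open, it means among the compounds named here.

Within the data shown here, in a functional assay on A549 cells (Homo sapiens) for antiproliferative activity, read by MTT assay, with a stated time of 72 h (on this read-out lower numbers stand for stronger inhibition and higher numbers for weaker inhibition), compound 3 `O=C(N/N=C/c1ccc([N+](=O)[O-])cc1)Nc1ccc(Oc2ccnc3[nH]ccc23)cc1` gives 2100 nM, the second highest of the three numbers so far. Compound 2 `O=C(N/N=C/c1ccc(Br)cc1)Nc1ccc(Oc2ccnc3[nH]ccc23)cc1` gives 640 nM, and compound 1 `O=C(N/N=C/c1ccccc1)Nc1ccc(Oc2ccnc3[nH]ccc23)cc1` gives 17200 nM.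

The next structure is compound 4 `O=C(N/N=C/c1cccc(Cl)c1Cl)Nc1ccc(Oc2ccnc3[nH]ccc23)cc1`: 2,3-dichlorophenyl in place of 4-nitrophenyl on a carbon with a double bond to nitrogen. In words, 2,3-dichlorophenyl stands in place of 4-nitrophenyl on a carbon with a double bond to nitrogen.

Among the measured compounds shown here, three measured steps bear on this change. Adding a ring substituent lowered the number both times, with a 27-fold lower number from compound 1 to compound 2 (1.43 log units; beyond the scatter) for bromo and an 8.2-fold lower number from compound 1 to compound 3 (0.91 log units; beyond the scatter) for nitro. The two substituted rings are separated by a 3.3-fold higher number from compound 2 to compound 3 (0.52 log units; beyond the scatter). For the measured compounds named here, no measured compound carries chlorine or two ring substituents, so the support is indirect. Going by the values given here, a modest step to a lower number is expected in this assay, with the halogen-bearing compound 2 at 640 nM as the only guide. The estimated change is a 1.9-fold lower number from compound 3 to compound 4 (0.28 log units; within the scatter). Compound 4 is expected at 1100 nM, within an estimated range of 350 nM to 3500 nM.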

Compound 4, half-maximal inhibitory concentration: "not active" (no number reported)
Compound 4: no number reported; the estimate stays without a comparison.
By their numbers in this assay, from the lowest: compound 2; then compound 3; then compound 1.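

In this assay, among these compounds, compound 4 is recorded as "not active" without a number, so no step to compound 4 from compound 1, compound 2 or compound 3 can be read. The compounds shown leave open how far 2,3-dichlorophenyl differs from 4-nitrophenyl in this read-out. No supporting data bear on this result.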